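Changing the aryl group on the ring nitrogen

The source may report more compounds than this note shows. Statements on the series, on what has been measured and on what is new or still open speak of the compounds shown alone.

Measured compounds:
compound 1, `N#CC1=C(N)Oc2c(c3nc4ccccc4nc3c3ccccc23)C12C(=O)N(Cc1cnnn1-c1cc(Cl)ccc1Cl)c1ccccc12`: > 50000 nM (a limit)
compound 2, `N#CC1=C(N)Oc2c(N)cc3nc4ccccc4nc3c2C12C(=O)N(Cc1cnnn1-c1ccccc1Br)c1ccccc12`: 27400 nM

In a functional assay on A549 cells (Homo sapiens) for antiproliferative activity, read by MTT assay, with a stated time of 48 h (on this read-out higher numbers stand for weaker inhibition and lower numbers for stronger inhibition), compound 1 reaches only a limit, > 50000 nM. Among the measured compounds shown here, compound 2 is the one compound with a number in this assay, 27400 nM. Compound 1 stands at the limit of > 50000 nM in this assay, at which 1 of the 2 values shown sits. Compound 3, `Cc1ccc(-n2nncc2CN2C(=O)C3(C(C#N)=C(N)Oc4c(N)cc5nc6ccccc6nc5c43)c3ccccc32)cc1Cl`, differs from compound 2 by 3-chloro-4-methylphenyl in place of 2-bromophenyl on an aromatic nitrogen. For the measured compounds named here, no measured pair shows the effect of such a change, so one expects a shift of about a 1.1-fold higher number from compound 2 to compound 3 (0.04 log units; within the scatter), which lies within the scatter. For compound 3 the estimated value in this assay is 30000 nM, with a range from 10000 nM to 80000 nM.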

Compound 3, half-maximal inhibitory concentration: 11800 nM
Compound 3: middle estimate off by 2.5-fold (0.41 log units), on the high side, within the range that was stated.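

Among the compounds shown here, this is the first step that can be read at this position: in this assay, 3-chloro-4-methylphenyl in place of 2-bromophenyl on an aromatic nitrogen gives a 2.3-fold lower number from compound 2 to compound 3 (0.37 log units; beyond the scatter). The aryl group here therefore affects the read-out, although the step is modest. Nothing available explains why the number falls. The compounds shown leave open whether the chlorine, the methyl group or the loss of bromine accounts for the step. They also leave open how a phenyl ring carrying an amine or a carboxylic acid would read here.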